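Swapping the Chain End on a Shared Core

The source may report more compounds than this note shows. Statements on the series, on what has been measured and on what is new or still open speak of the compounds shown alone.

Measured in a functional assay on HT cells (Homo sapiens) for antiproliferative activity, read by fluorescence, with a stated time of 72 h; on this read-out higher numbers stand for weaker inhibition of growth and lower numbers for stronger inhibition of growth:
- compound 1 `CC(C)c1n[nH]c2c(NCc3ccc(-c4ccccn4)cc3)nc(SCC(O)CN3CCNCC3)nc12`: 332 nM
- compound 2 `CC(C)c1n[nH]c2c(NCc3ccc(-c4ccccn4)cc3)nc(SCCN)nc12`: 22 nM
- compound 3 `CC(C)c1n[nH]c2c(NCc3ccc(-c4ccccn4)cc3)nc(SCCNC(=N)N)nc12`: 390 nM

Compound 3 sits at the weak end of this small set. It shows a 1.2-fold higher number from compound 1 to compound 3 (0.07 log units; within the scatter), so it cannot be told apart from compound 1 in this assay. Compound 2 stands well clear of both, with a 15-fold lower number from compound 1 to compound 2 (1.18 log units; beyond the scatter) and an 18-fold higher number from compound 2 to compound 3 (1.25 log units; beyond the scatter).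

The next compound is compound 4 `CC(C)c1n[nH]c2c(NCc3ccc(-c4ccccn4)cc3)nc(SCC(C)(C)N)nc12`, and the change is a group of 4 heavy atoms (3 carbon, 1 nitrogen; no ring) in place of a group of 5 heavy atoms (2 carbon, 3 nitrogen; no ring), on a saturated chain carbon bound to a sulfur. The new 1-amino-1-methylethyl group sits on a saturated chain carbon bound to a sulfur, the same place that carries aminomethyl in compound 2. The most relevant evidence is therefore the large step of an 18-fold higher number from compound 2 to compound 3 (1.25 log units; beyond the scatter), which links the guanidine-bearing compound 3 to the free amine of compound 2. Going by the values given here, no measured step separates aminomethyl from 1-amino-1-methylethyl, so compound 4 need not recover all of that gap. The result for compound 1 also shows that not every replacement of aminomethyl at this place keeps the low number of compound 2.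

A large step downward, beyond the scatter, is still expected, and the estimate is an 8.7-fold lower number from compound 3 to compound 4 (0.94 log units; beyond the scatter). Compound 4 is expected at about 45 nM, with an estimated range of 14 nM to 140 nM.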

Compound 4, concentration for 50% growth inhibition: 85 nM
The estimate for compound 4 lay 1.9-fold (0.28 log units) below the measured number; measured number inside the range.
By their numbers in this assay, from the lowest: compound 2; then compound 4; then compounds 1 and 3 (each within the scatter of the next).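

On a saturated chain carbon bound to a sulfur, 1-amino-1-methylethyl in place of aminomethyl gives a 3.9-fold higher number from compound 2 to compound 4 (0.59 log units; beyond the scatter) in this assay and thus shows that a change at this place can move the number beyond the scatter even when the chain end still carries its amine. That step is modest, however, and compound 4 stays clearly apart from the other two chain ends, with a 4.6-fold lower number from compound 3 to compound 4 (0.66 log units; beyond the scatter) against the guanidine-bearing compound and a 3.9-fold lower number from compound 1 to compound 4 (0.59 log units; beyond the scatter) against the 1-hydroxy-2-(piperazin-1-yl)ethyl compound. The order of the four compounds therefore rests on the numbers alone, since nothing shown accounts for any of these differences.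

What the compounds shown leave open is how the number would run with 1-aminoethyl, with a longer chain ending in an amine, or with a dimethylamino group at the chain end in place of aminomethyl. They also leave open whether a carboxylic acid at this place, which would carry no amine at all, would fall near compound 2 or near compound 3.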